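Will a New Phenyl Group Move Compound 2?

This account rests on a few compounds, and the source may have more. Where it says the series, first, only, none or still open, it means among the compounds named here.

Of the compounds shown here, two with a shared core have numbers so far in a functional assay on MCF7 cells (Homo sapiens) for inhibition, read by CCK-8 assay, with a stated time of 48 h; a higher number here means a weaker inhibitor of growth, a lower number a stronger inhibitor of growth. Compound 1 (`COc1ccc(CNc2nc(Nc3ccc(N4CCN(C)CC4)cn3)ncc2Cl)cc1`) gives 17300 nM, and compound 2 (`Cc1ccc(Nc2nc(Nc3ccc(N4CCN(C)CC4)cn3)ncc2Cl)cc1`) gives 11400 nM. These two values lie within the usual scatter of repeated measurements, so the data cannot separate compound 2 from compound 1.

The next structure is compound 3 (`CC(C)c1cccc(Nc2nc(Nc3ccc(N4CCN(C)CC4)cn3)ncc2Cl)c1`), which carries 3-isopropylphenyl in place of 4-methylphenyl on a nitrogen on an aromatic ring. The change counts as follows: 3-isopropylphenyl in place of 4-methylphenyl on a nitrogen on an aromatic ring.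

Among the measured compounds shown here, only one measured step bears on this change, since it also exchanged the group at that place. That step, a 1.5-fold lower number from compound 1 to compound 2 (0.18 log units; within the scatter), put 4-methylphenyl in place of 4-methoxybenzyl and stayed within the scatter. A single step is thin evidence, but it gives no reason to predict a large shift. No move beyond the scatter is therefore expected in this assay, and the estimated step is a 1.2-fold lower number from compound 2 to compound 3 (0.08 log units; within the scatter). Compound 3 is expected at 9500 nM, with an estimated range of 3500 nM to 22000 nM.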

Compound 3, concentration for 50% growth inhibition: 8640 nM
The estimate for compound 3 lay 1.1-fold (0.04 log units) above the measured number, within the range that was stated.
By their numbers in this assay, from the lowest: compounds 3, 2 and 1 (each within the scatter of the next).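

In this assay, putting 3-isopropylphenyl in place of 4-methylphenyl on a nitrogen on an aromatic ring gives a 1.3-fold lower number from compound 2 to compound 3 (0.12 log units; within the scatter), so a swap between two groups made only of carbon also stays inside the normal spread of repeat measurements. The remaining pair gives a 2.0-fold lower number from compound 1 to compound 3 (0.30 log units; within the scatter), which means that none of the three groups at this place can yet be told apart, and compound 1, compound 2 and compound 3 cannot be ranked in this read-out. Nothing available here offers an explanation for these small steps.

On these data alone, what remains open is whether this place can affect growth inhibition at all, for example if the ring on this nitrogen carried a carboxylic acid, a primary amine or a longer chain ending in an amine. The compounds shown also share everything outside this one place, so they leave unanswered whether a change elsewhere in the shared core would produce a step beyond the scatter.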